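The compounds below may be only part of what the source reports. "The series", "measured", "known", "first", "only" and "open" are said of these compounds alone.

Measured compounds:
Compound 1 `Cc1ccc(-c2ccc(C)n2-c2ccc(-c3nc4ccccc4s3)cc2)cc1` — in a functional assay on MDA-MB-231 cells (Homo sapiens) for cytotoxicity, read by sulforhodamine B assay, with a stated time of 48 h (on this read-out higher numbers stand for weaker inhibition of growth and lower numbers for stronger inhibition of growth), compound 1 gives 4400 nM
Compound 2 `COc1ccc(-c2ccc(C)n2-c2ccc(-c3nc4ccccc4s3)cc2)cc1` — compound 2 gives 3990 nM
Compound 3 `Cc1ccc(-c2ccc(C)n2-c2ccc(-c3nc4ccc(F)cc4s3)cc2)cc1` — compound 3 gives 3140 nM

Compound 3 has the lowest of the three numbers, but its nearest neighbour, compound 2, and its furthest, compound 1, both lie within the scatter of it, so no order among the three can be stated.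

Compound 4 `COc1ccc(-c2ccc(C)n2-c2ccc(-c3nc4ccc(F)cc4s3)cc2)cc1` differs from compound 3 in one place: methoxy in place of methyl on an aromatic carbon. The same change has been measured once in this set, between two compounds that share the unsubstituted benzothiazole side of the core: a 1.1-fold lower number from compound 1 to compound 2 (0.04 log units; within the scatter). The fluoro that compound 3 and compound 4 carry was itself introduced by a step that changed little, a 1.4-fold lower number from compound 1 to compound 3 (0.15 log units; within the scatter). Both exchanges have therefore moved the read-out only within the scatter, and nothing in the data suggests that combining them behaves otherwise.

For compound 4 a step of a 1.1-fold lower number from compound 3 to compound 4 (0.04 log units; within the scatter) in this assay is expected, that is, no change beyond the scatter. The estimate for compound 4 is 2850 nM, with a range from 1500 nM to 5500 nM.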

Compound 4, concentration for 50% growth inhibition: 3070 nM
The estimate for compound 4 lay 1.1-fold (0.03 log units) below the measured number; the range from low to high includes it.
By their numbers in this assay, from the lowest: compounds 4, 3, 2 and 1 (each within the scatter of the next).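

In this assay, the exchange of 4-methylphenyl for 4-methoxyphenyl, para to a large group, gives a 1.0-fold lower number from compound 3 to compound 4 (0.01 log units; within the scatter) on the fluoro-bearing core, so this position has now been read on two cores and the change stays within the scatter on both: the same change on two cores in this assay, a 1.1-fold lower number (0.04 log units; within the scatter) from compound 1 to compound 2 and a 1.0-fold lower number (0.01 log units; within the scatter) from compound 3 to compound 4, 1.1-fold (0.03 log units) apart, within the scatter of two such steps.

Among these compounds, the fluoro, so far seen only with the methyl group, has now also been read with the methoxy group, where it gives a 1.3-fold lower number from compound 2 to compound 4 (0.11 log units; within the scatter) and again stays within the scatter: the same change on two cores in this assay, a 1.4-fold lower number (0.15 log units; within the scatter) from compound 1 to compound 3 and a 1.3-fold lower number (0.11 log units; within the scatter) from compound 2 to compound 4, 1.1-fold (0.03 log units) apart, within the scatter of two such steps.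

Taken together, these steps show that in this small set neither exchange alters the read-out of the other beyond the scatter, so the methoxy and fluoro changes can be read as independent of each other here.

As far as these compounds go, what remains open is whether a group of another kind at this position, such as an amine, a carboxylic acid or a longer chain like butoxy, would move the number beyond the scatter. It is equally open whether chloro or trifluoromethyl in place of the fluoro would do so, as every step shown here lies within the scatter and none marks out a change that matters on the shared core.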